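This account rests on a few compounds, and the source may have more. Where it says the series, first, only, none or still open, it means among the compounds named here.

Measured so far: compound 1 `O=C(NO)c1ccc(NCc2nc(-c3ccc(Br)cc3)nn2-c2ccccc2)cc1`, 54.7%; compound 2 `O=C(NO)c1ccc(NCc2nc(-c3ccccc3)nn2-c2ccc(Br)cc2)cc1`, 65.9%; compound 3 `O=C(NO)c1ccc(NCc2nc(-c3ccccc3)nn2-c2cccc(Cl)c2)cc1`, 62.3%.

In an assay on Sf9 cells for inhibition of protein deacetylase HDAC6 (Homo sapiens), read by fluorescence, with a stated time of 40 min, tested at 100 nM (on this read-out higher numbers stand for more inhibition at the one concentration tested (going by the name of the read-out) and lower numbers for less inhibition), compound 1 holds the lowest of the three numbers; compound 3 lies within the scatter of it, and compound 2 lies beyond it. Compound 4 `CC(C)c1ccc(-c2nc(CNc3ccc(C(=O)NO)cc3)n(-c3ccccc3)n2)cc1` differs from compound 1 by a single change: isopropyl in place of bromo on an aromatic carbon. Within the data shown here, the one measured step, a number 3.6 percentage points lower from compound 2 to compound 3 (within the scatter), alters the aryl group on an aromatic nitrogen, not the ring that carries the bromo in compound 1, so no measured step bears on this change. No step beyond the scatter is therefore expected, and the estimated step is a number 2.3 percentage points higher from compound 1 to compound 4 (within the scatter). For compound 4 the expected value in this assay is 57%, with a range from 42% to 72%.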

Compound 4, a percentage reported as inhibition, at one concentration (the size of the read-out at that concentration, not a potency): 27.6%
Compound 4: middle estimate off by 29.4 percentage points, on the high side, outside the stated range (below it).
By their numbers in this assay, from the lowest: compound 4; then compounds 1, 3 and 2 (each within the scatter of the next, the first and the last beyond it).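

In this assay, among these compounds, the change from 4-bromophenyl to 4-isopropylphenyl gives a number 27.1 percentage points lower from compound 1 to compound 4 (beyond the scatter) and is the first measured step at this position. The number here thus responds to the group on this aromatic carbon, even though a bromine atom gives way to three carbon atoms with no hydrogen-bond donor, acceptor or charge entering or leaving. Nothing available explains this drop.

On these data alone, whether methyl, chloro, methoxy or an amine at this place would stay with compound 1 or fall with compound 4 remains open. So does the effect of isopropyl on the aryl group on the aromatic nitrogen.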